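Nitro on the pendant aryl ring of compound 2

This account rests on a few compounds, and the source may have more. Where it says the series, first, only, none or still open, it means among the compounds named here.

Measured so far in a functional assay on the whole organism with Mus musculus as the target (a higher number here means that more compound is needed for the effect, a lower number that less compound is needed), are three compounds:
- compound 1 `COc1cc2c(cc1OC)C(c1ccc([N+](=O)[O-])cc1)=NN=C(S)C2` gives 69.8 umol/kg
- compound 2 `COc1cc2c(cc1OC)C(c1ccccc1)=NN(C)C(=S)C2` gives 24.7 umol/kg
- compound 3 `COc1cc2c(cc1OC)C(c1ccc(Cl)cc1)=NNC(=O)C2` gives 75.3 umol/kg

Compound 2 has the lowest of the three numbers, and compound 1 and compound 3 each stand higher by more than the usual scatter. The next structure is compound 4 `COc1cc2c(cc1OC)C(c1ccc([N+](=O)[O-])cc1)=NN(C)C(=S)C2` and the change from compound 2 is nitro in place of hydrogen on an aromatic carbon with nitro in place of hydrogen on an aromatic carbon, para to a large group.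

Among the compounds with values here, no two measured compounds differ in one place only, so the size of this change has not been seen directly in this assay and the guidance is indirect. Compound 1 also carries nitro and gives 69.8 umol/kg but it differs from compound 2 in more than one place, so that number cannot be credited to nitro alone. Within the data shown here, a small rise in the number is expected, with no step clearly beyond the scatter. The expected change is a 1.3-fold higher number from compound 2 to compound 4 (0.11 log units; within the scatter) as an estimate only. For compound 4 the estimate in this assay is 32 umol/kg with an expected range from 13 umol/kg to 78 umol/kg until the measurement is available.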

Compound 4, dose for half-maximal effect: 81.5 umol/kg
Compound 4: middle estimate off by 2.5-fold (0.41 log units), on the low side; the measured number lies above the stated range.
By their numbers in this assay, from the lowest: compound 2; then compounds 1, 3 and 4 (each within the scatter of the next).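

In this assay, nitro in place of hydrogen on an aromatic carbon, para to a large group, now has a direct reading: a 3.3-fold higher number from compound 2 to compound 4 (0.52 log units; beyond the scatter). Within the data shown here, this is the first single-place step, and it shows that this position of the aromatic ring is not neutral to substitution, since the change costs a step beyond the scatter with the rest of compound 2 left intact. Nothing shown here gives a reason for the rise, so the step stands as an observation about nitro at this one place only.

One pair cannot tell whether the rise belongs to nitro itself or to any group replacing hydrogen at this position, and an amine, a carboxylic acid or a short alkyl chain such as ethyl at the same carbon would help to separate the two. It also remains open whether the same replacement gives a step of similar size on the other cores in the series, where the matching hydrogen compound or nitro compound is absent from the set shown.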